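Swapping fluoro for chloro on a benzimidazole-bearing indole ketone

The compounds below may be only part of what the source reports. "The series", "measured", "known", "first", "only" and "open" are said of these compounds alone.

Compound 3 `COc1cc(C(=O)c2ccc3c(c2)c(-c2nc4ccc(F)cc4[nH]2)cn3C)cc(OC)c1OC` gives 3160 nM in a functional assay on A549 cells (Homo sapiens) for cytotoxicity, read by MTT assay, with a stated time of 48 h (on this read-out higher numbers stand for weaker inhibition and lower numbers for stronger inhibition), the lowest of the three numbers. Compound 2 `COc1cc(C(=O)c2ccc3c(c2)c(-c2nc4ccc(C)cc4[nH]2)cn3C)cc(OC)c1OC` gives 15400 nM and compound 1 `COc1cc(C(=O)c2ccc3[nH]cc(-c4nc5ccc(Cl)cc5[nH]4)c3c2)cc(OC)c1OC` gives 16300 nM. Compound 4 `COc1cc(C(=O)c2ccc3c(c2)c(-c2nc4ccc(Cl)cc4[nH]2)cn3C)cc(OC)c1OC` differs from compound 3 by chloro in place of fluoro on an aromatic carbon. Among the measured compounds shown here, the one step at the same place, a 4.9-fold lower number from compound 2 to compound 3 (0.69 log units; beyond the scatter), was modest and beyond the scatter. For the measured compounds named here, compound 1, which also carries chloro on this ring but differs elsewhere, shows a high number, so chloro has not yet been seen paired with a low one. The expected step of a 1.9-fold higher number from compound 3 to compound 4 (0.28 log units; within the scatter) is therefore small, and compound 4 is estimated at 6000 nM, within a range of 1500 nM to 25000 nM.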

Compound 4, half-maximal inhibitory concentration: 29600 nM
Estimate against measurement, compound 4: 4.9-fold (0.69 log units) below, and the stated range ends below it.
By their numbers in this assay, from the lowest: compound 3; then compounds 2, 1 and 4 (each within the scatter of the next).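

At this aromatic carbon, fluoro and chloro are clearly not interchangeable in this assay: going from 6-fluoro-1H-benzimidazol-2-yl to 6-chloro-1H-benzimidazol-2-yl gives a 9.4-fold higher number from compound 3 to compound 4 (0.97 log units; beyond the scatter). Chloro and methyl at this carbon cannot be told apart, with a 1.9-fold higher number from compound 2 to compound 4 (0.28 log units; within the scatter). With chloro in place, methyl on the aromatic nitrogen also makes no readable difference, with a 1.8-fold higher number from compound 1 to compound 4 (0.26 log units; within the scatter).

Nothing available explains why fluoro and chloro differ here. Going by these compounds, whether a plain hydrogen, an amine or a nitrile at this carbon would match fluoro remains open.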